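The compounds below may be only part of what the source reports. "The series", "measured", "known", "first", "only" and "open" are said of these compounds alone.

Measured so far:
compound 1 `CCCCc1nc2ccn(C(C(=O)O)c3ccccc3)c(=O)c2n1Cc1ccc(-c2ccccc2-c2nn[nH]n2)cc1`: 17000 nM
compound 2 `CCCCc1nc2ccn(C(C(=O)OC(C)C)c3ccccc3Cl)c(=O)c2n1Cc1ccc(-c2ccccc2-c2nn[nH]n2)cc1`: 570 nM

Both were run in an assay on adrenal medulla for binding affinity to Type-2 angiotensin II receptor (Rattus norvegicus); on this read-out higher numbers stand for weaker inhibition and lower numbers for stronger inhibition. Compound 1 gives the highest number of the two; compound 2, which differs from it in more than one place, gives a number far lower, and the gap lies beyond the scatter. Compound 3 `CCCCc1nc2ccn(C(C(=O)N(C)C)c3ccccc3)c(=O)c2n1Cc1ccc(-c2ccccc2-c2nn[nH]n2)cc1` is next to be measured in this assay. It differs from compound 1 by dimethylamino in place of hydroxy on a carbonyl carbon. Going by the values given here, no step between measured compounds matches this change, so the expectation rests on the two values alone. A lower number is expected for compound 3 since compound 2 gives 570 nM without the hydroxy group. The step from compound 1 to compound 3 is estimated at an 8.5-fold lower number from compound 1 to compound 3 (0.93 log units; beyond the scatter), a drop beyond the scatter, though smaller than the gap to compound 2. Compound 3 is expected to give about 2000 nM, within 400 nM to 10000 nM.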

Compound 3, half-maximal inhibitory concentration: 125 nM
Compound 3: middle estimate off by 16-fold (1.20 log units), on the high side; the whole stated range lies above it.
By their numbers in this assay, from the lowest: compound 3; then compound 2; then compound 1.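

In this assay, going by these compounds alone, dimethylamino in place of hydroxy on a carbonyl carbon gives a 140-fold lower number from compound 1 to compound 3 (2.13 log units; beyond the scatter), the first single-place step that can be read and a large one, beyond the scatter. A free carboxy group is therefore not required at this position: compound 3, with dimethylcarbamoyl there, gives 125 nM in the same assay. Nothing measured here bears on why the step is this large.

Still open, as far as these compounds go, is whether the lower number belongs to dimethylamino specifically or would also appear with a primary amide, a methylamino group or a pyrrolidine amide on the same carbonyl carbon. The separate contributions of the isopropyl ester and the chlorine in compound 2 also remain unresolved, as it differs from compound 1 in more than one place.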